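Isobutoxy versus hydroxyethoxy on a shared core

The source may hold more compounds than are shown below. What is called first, only, known or untested is meant among the compounds shown, and "the series" means these compounds.

Measured so far:
compound 1 `COCCOc1ccc2c(Oc3ccc(Nc4nccc5[nH]cc(-c6ccc(F)cc6)c(=O)c45)cc3F)ccnc2c1` — 1.73 h
compound 2 `O=c1c(-c2ccc(F)cc2)c[nH]c2ccnc(Nc3ccc(Oc4ccnc5cc(OCCO)ccc45)c(F)c3)c12` — 1.51 h

In an ADME assay on microsomes from liver (Rattus norvegicus) for metabolic stability (a lower number here means that the compound disappears faster, a higher number that the compound lasts longer), compound 2 gives the lowest of the two numbers, though a 1.1-fold lower number from compound 1 to compound 2 (0.06 log units; within the scatter) places it level with compound 1. Compound 3 `CC(C)COc1ccc2c(Oc3ccc(Nc4nccc5[nH]cc(-c6ccc(F)cc6)c(=O)c45)cc3F)ccnc2c1` is not yet measured; it differs from compound 2 by isopropyl in place of hydroxymethyl on a saturated chain carbon bound to an oxygen on an aromatic ring. Among the compounds with values here, the only step at hand, a 1.1-fold lower number from compound 1 to compound 2 (0.06 log units; within the scatter), is a different change at the same chain, so the data give no firm direction for a larger replacement. Compound 3 is therefore expected to land near compound 2, with a step of a 1.1-fold lower number from compound 2 to compound 3 (0.03 log units; within the scatter) and an estimated 1.4 h spanning 0.7 h to 2.8 h.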

Compound 3, half-life: 1.5 h
Beside the measured number, compound 3's estimate is 1.1-fold (0.03 log units) below it, and the stated range covers the measured number.
By their numbers in this assay, from the lowest: compounds 3, 2 and 1 (each within the scatter of the next).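

In this assay, isopropyl in place of hydroxymethyl on a saturated chain carbon bound to an oxygen on an aromatic ring gives a 1.0-fold lower number from compound 2 to compound 3 (0.00 log units; within the scatter), and isopropyl in place of methoxymethyl gives a 1.2-fold lower number from compound 1 to compound 3 (0.06 log units; within the scatter). At this position, then, 2-hydroxyethoxy and isobutoxy read alike, although the entering isopropyl has no hydrogen-bond donor or acceptor and the leaving hydroxymethyl has one of each. Nothing available explains this result. Going by these compounds, whether an amine, a carboxylic acid or a longer chain at this place would move the half-life remains open.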